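Series notes: clearance expected for compound 3

The source may report more compounds than this note shows. Statements on the series, on what has been measured and on what is new or still open speak of the compounds shown alone.

Measured so far in an in vivo ADME assay on the whole organism (strain 129/SvEvBrd x C57BL/6) for pharmacokinetics, with Mus musculus as the target, at a dose of 1 mg/kg by the intravenous route (on this read-out lower numbers stand for slow clearance and higher numbers for fast clearance), are:
- compound 1 `CC(=O)c1nc([C@@H](O)[C@H](O)[C@H](O)CO)c(-c2ccccc2)[nH]1` with 23.9 mL/min/kg as clearance
- compound 2 `CC(O)c1nc([C@@H](O)[C@H](O)[C@H](O)CO)c[nH]1` with 16.4 mL/min/kg as clearance

Compound 2 stands within the scatter of compound 1, so these values set no order between the two. Within the data shown here, the next structure is compound 3 `Cc1nc(-c2nc([C@@H](O)[C@H](O)[C@H](O)CO)c[nH]2)cs1`, and it differs from compound 2 by 2-methyl-1,3-thiazol-4-yl in place of 1-hydroxyethyl on an aromatic carbon as the single change. In short, 2-methyl-1,3-thiazol-4-yl stands in place of 1-hydroxyethyl on an aromatic carbon.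

Among the measured compounds shown here, no measured pair differing in one place shows the size of such a change in this assay directly. For the measured compounds named here, the only guide is that compound 1 gives 23.9 mL/min/kg and compound 2 gives 16.4 mL/min/kg as values within the scatter of each other. The expected step is a 1.2-fold higher number from compound 2 to compound 3 (0.09 log units; within the scatter) and it is not expected to go beyond the scatter in either direction. The estimate for compound 3 is 20 mL/min/kg as the expected value, with an expected range from 8 mL/min/kg to 45 mL/min/kg for the measurement.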

Compound 3, clearance: 19.4 mL/min/kg
For compound 3 the middle estimate is 1.0-fold (0.01 log units) above the measured one; the measured number falls inside the stated range.
By their numbers in this assay, from the lowest: compounds 2, 3 and 1 (each within the scatter of the next).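

In this assay, among these compounds, the first comparison that differs in one place puts 2-methyl-1,3-thiazol-4-yl in place of 1-hydroxyethyl on the aromatic carbon between two ring nitrogen atoms, and it gives a 1.2-fold higher number from compound 2 to compound 3 (0.07 log units; within the scatter) as the step. At this position, therefore, a larger group with a five-membered aromatic ring and no hydrogen-bond donor gives clearance that cannot be told apart from that with 1-hydroxyethyl. Nothing measured on these compounds gives a reason for this result.

On these data alone, whether an amine, a carboxylic acid or a longer chain on this carbon would take clearance beyond the scatter remains open. As far as these compounds go, the separate contribution of the phenyl group in compound 1 also remains open, as compound 1 differs from compound 2 and compound 3 in more than one place.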